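Cyanoguanidine series: benzyl to phenylsulfanyl on the side chain

The source may hold more compounds than are shown below. What is called first, only, known or untested is meant among the compounds shown, and "the series" means these compounds.

Measured so far:
Compound 1, `N#C/N=C(\NCCCc1ccccc1)NCCCc1c[nH]cn1`: 5.25
Compound 2, `N#C/N=C(/NCCCc1c[nH]cn1)NCCC(c1ccccc1)c1ccccc1`: < 5 (a limit)
Compound 3, `N#C/N=C(/NCCCc1c[nH]cn1)NCCCC1CCCCC1`: < 5; < 5 (2 entries) (both entries limits)

For the measured compounds named here, in an in vitro functional assay on Sf9 cells for antagonist activity at histamine H2 receptor (Homo sapiens) (a lower number here means a less potent compound, a higher number a more potent compound, by a factor of ten per unit of this negative logarithm), compound 1 gives 5.25, the only single number in the set. Compound 2 in this assay reaches only < 5, which is a limit of the assay and not a number. Compound 3 in this assay likewise stops at < 5; < 5 (2 entries) in both entries, again a limit. Going by the values given here, the one measured step, a number at least 0.25 log units lower from compound 1 to compound 2 (that floor lies within the scatter), thus has a floor that lies within the scatter, so its true size is open; the limit of < 5 in this assay, at which 1 of the 3 values shown sits, marks where the measured values run out.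

Compound 4, `N#C/N=C(/NCCCc1c[nH]cn1)NCCSc1ccccc1`, differs from compound 1 by phenylsulfanyl in place of benzyl on a saturated chain carbon, two bonds along the chain from an amine nitrogen. Among the compounds with values here, no measured step changes this part of the chain in the same way, and the step from compound 1 to compound 2 adds a group rather than exchanging one, so it bears only loosely. Within the data shown here, with a group of the same heavy-atom count on the chain and no measured precedent for a large move, compound 4 is expected to stay near compound 1 in this assay, the step of a number 0.05 log units lower from compound 1 to compound 4 (within the scatter) being the estimate. Compound 4 is estimated at 5.2, within 4.6 to 5.8.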

Compound 4, negative logarithm of the antagonist equilibrium constant: < 5
Compound 4 was reported as a limit; the forecaster's own chance of this, stated with the estimate: 35%; middle value at least 0.20 log units from the limit.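

In this assay compound 4 gives < 5, which is a limit of the assay and not a number. At this position, the exchange of benzyl for phenylsulfanyl keeps the heavy-atom count and the six-membered aromatic ring of carbon only, yet it gives a number at least 0.25 log units lower from compound 1 to compound 4 (that floor lies within the scatter), so the data do not establish a real loss, but neither do they show that the exchange preserves a measurable value. Unlike compound 2, which adds a phenyl group to the chain, compound 4 extends the limit to an exchange within the chain, and compound 1 remains the only compound here with a single number: the limit of < 5 in this assay, at which 2 of the 4 values shown sit.

The true size of the step remains open, and the compounds shown cannot separate the effect of the sulfur atom from that of the altered chain. Also open, on these data alone, is whether a phenoxy group or a longer chain ending in phenylsulfanyl at this position would give a number rather than a limit in this assay.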